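From a Chlorinated Benzyl Ether to a Methoxy Analogue

The source may report more compounds than this note shows. Statements on the series, on what has been measured and on what is new or still open speak of the compounds shown alone.

Within the data shown here, compound 2 `COc1cccc(OC)c1OCCNCCOc1ccccc1OCc1ccccc1Cl` gives 1.41 nM in an assay on CHO cells for displacement of a labelled ligand from Alpha-1A adrenergic receptor (Homo sapiens) (on this read-out lower numbers stand for stronger inhibition and higher numbers for weaker inhibition), the higher of the two numbers measured so far; compound 1 `COc1cccc(OC)c1OCCNCCOc1ccccc1OCc1ccccc1` gives 0.468 nM. Among the measured compounds shown here, the only measured step is a 3.0-fold higher number from compound 1 to compound 2 (0.48 log units; beyond the scatter). Compound 3 `COc1cccc(COc2ccccc2OCCNCCOc2c(OC)cccc2OC)c1` differs from compound 2 in one place: 3-methoxyphenyl in place of 2-chlorophenyl on a saturated chain carbon bound to an oxygen on an aromatic ring. No measurement speaks to a 3-methoxyphenyl group, but the measured step shows that chloro entering raised the number, so removing the 2-chlorophenyl group is expected to bring the number back toward that of compound 1. The expected step is a 1.8-fold lower number from compound 2 to compound 3 (0.25 log units; within the scatter). Compound 3 is therefore estimated at 0.8 nM, within 0.3 nM to 2.5 nM.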

Compound 3, inhibition constant: 2 nM
The estimate for compound 3 lay 2.5-fold (0.40 log units) below the measured number; low and high end bracket the measured number.
By their numbers in this assay, from the lowest: compound 1; then compounds 2 and 3 (each within the scatter of the next).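

In this assay, compounds carrying the 2-chlorophenyl and 3-methoxyphenyl groups on this chain carbon cannot be told apart, with a 1.4-fold higher number from compound 2 to compound 3 (0.15 log units; within the scatter). Methoxy in place of hydrogen gives a 4.3-fold higher number from compound 1 to compound 3 (0.63 log units; beyond the scatter), so on this ring the methoxy group, like chloro, raises the number. No evidence is available to explain these results.

The swap alters both the group and its place on the ring, so the effects of the two cannot be separated. On these data alone, how an amine or a carboxylic acid on this ring would behave remains open.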